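A few compounds are considered here, and "the series" means these few. Any claim that something is new, unique, unknown or untested is made for them only; others in the source may bear on it.

In a functional assay on U-251 cells (Homo sapiens) for inhibition, read by sulforhodamine B assay, with a stated time of 48 h (a lower number here means a stronger inhibitor of growth, a higher number a weaker inhibitor of growth), two compounds have been measured so far:

Compound 1 `COc1ccc(NC(=S)N/N=C/c2cccs2)cc1`: > 100000 nM (a limit)
Compound 2 `CCc1ccc(NC(=S)N/N=C/c2cccs2)cc1`: > 100000 nM (a limit)

Compound 2 stands at > 100000 nM, and this is a limit of the assay, not a number. The whole record so far is the limit of > 100000 nM in this assay, at which 2 of the 2 values shown sit, so no measured number places compound 2 relative to compound 1.

Compound 3 `S=C(N/N=C/c1cccs1)Nc1ccc(Br)cc1` keeps the shared core of compound 2 and differs from it in one place: bromo in place of ethyl on an aromatic carbon. This puts bromo in place of ethyl on an aromatic carbon, para to a large group.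

For the measured compounds named here, only one measured step bears on this change, a step that the two limits leave unreadable from compound 1 to compound 2, which is also a swap of one group on an aromatic carbon. Its size cannot be read, so it offers no magnitude or direction to carry over. No step beyond the scatter is therefore expected in this assay, and another limit would be no surprise.

The estimated change is a number no higher from compound 2 to compound 3 (the limit leaves the size open). For compound 3 the expected value is 100000 nM, within an estimated range of 30000 nM to 200000 nM.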

Compound 3, concentration for 50% growth inhibition: 4200 nM
Beside the measured number, compound 3's estimate is 24-fold (1.38 log units) above it; measured number outside the range, below it.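

In this assay, the earlier pair left it unclear whether the group on this aromatic carbon, para to a large group, matters at all, and compound 3 shows that it does. Bromo in place of ethyl gives an at least 23-fold lower number from compound 2 to compound 3 (1.37 log units; beyond the scatter), and bromo in place of methoxy at the same place gives an at least 23-fold lower number from compound 1 to compound 3 (1.37 log units; beyond the scatter), so a change in this one group is enough to bring the shared core from a limit to a measured number. Both steps are minimum sizes and their full extent cannot be read, because they start from a limit: the limit of > 100000 nM in this assay, at which 2 of the 3 values shown sit.

The compounds shown leave open whether this drop in the number belongs to bromo alone or would also come with chloro, iodo or trifluoromethyl at the same place, and whether a hydrogen there would fall with compound 3 or with compound 1 and compound 2. They also leave open how far the number for compound 3 depends on the rest of the shared core, since all three compounds keep that part unchanged.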